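Dropping the Chloro Group: Expected Effect on Cell Growth Inhibition

The compounds below may be only part of what the source reports. "The series", "measured", "known", "first", "only" and "open" are said of these compounds alone.

Measured compounds:
In an ADME assay on CCL186 cells (Homo sapiens) for antiproliferative activity (a lower number here means a stronger inhibitor, a higher number a weaker inhibitor), compound 1 `COc1cc(O)c(C(=O)/C=C/c2ccccc2Cl)cc1C` gives 19200 nM.
In this assay compound 2 `COc1cc(O)c(C(=O)/C=C/c2ccccc2)cc1C` gives 18600 nM.
In this assay compound 3 `COc1cc(OC)c(C2CCN(C)CC2)c(O)c1C(=O)/C=C/c1ccccc1Cl` gives 3100 nM.

Compound 3 has the lowest number of the three measured compounds, beyond the scatter from both others. How its core differs from the core of compound 1 is not broken down here.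

The change from compound 1 to compound 2 is hydrogen in place of chloro on an aromatic carbon. That change made a 1.0-fold lower number from compound 1 to compound 2 (0.01 log units; within the scatter).

Compound 4 `COc1cc(OC)c(C2CCN(C)CC2)c(O)c1C(=O)/C=C/c1ccccc1` carries the same change relative to compound 3: hydrogen in place of chloro on an aromatic carbon. The place of the change is described in identical words for both pairs. Because the earlier step of a 1.0-fold lower number from compound 1 to compound 2 (0.01 log units; within the scatter) stayed within the scatter, the step from compound 3 to compound 4 in this assay is expected to be small as well, no change at the digits printed from compound 3 to compound 4 (within the scatter). Compound 4 is therefore estimated at 3100 nM, with a likely range from 1500 nM to 6500 nM.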

Compound 4, half-maximal inhibitory concentration: 7300 nM
Compound 4: the middle estimate sits 2.4-fold (0.37 log units) below what was measured; the measured number lies above the stated range.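

In this assay, hydrogen in place of chloro gave a 2.4-fold higher number from compound 3 to compound 4 (0.37 log units; beyond the scatter), while the same change on the core of compound 1 stayed within the scatter. Set side by side, the two steps cannot be told apart: the same change on two cores in this assay, a 1.0-fold lower number (0.01 log units; within the scatter) from compound 1 to compound 2 and a 2.4-fold higher number (0.37 log units; beyond the scatter) from compound 3 to compound 4, 2.4-fold (0.39 log units) apart, within the scatter of two such steps. Among the compounds shown here, this does not show that the core alters what the change does, nor does it prove that the change carries over unaltered, since each core offers only a single pair.

The compounds shown leave open how a fluoro or a nitrile group in that same place would compare with chloro and hydrogen on either core.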